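Working notes: iodo in place of chloro

A few compounds are considered here, and "the series" means these few. Any claim that something is new, unique, unknown or untested is made for them only; others in the source may bear on it.

- compound 1 `O=c1[nH]c(=O)n(CC2(CO)CC2CO)cc1/C=C/Br` gives > 500 ug/mL as a limit
- compound 2 `O=c1[nH]c(=O)n(CC2(CO)CC2CO)cc1/C=C/Cl` gives > 500 ug/mL as a limit

In a functional assay on Vero cells (Chlorocebus sabaeus) for cytotoxicity (on this read-out higher numbers stand for lower toxicity in this test and lower numbers for higher toxicity in this test), compound 2 gives no number, only the limit of > 500 ug/mL in this assay, at which 2 of the 2 values shown sit, as its reading.

The change to compound 3 `O=c1[nH]c(=O)n(CC2(CO)CC2CO)cc1/C=C/I` is iodo in place of chloro on a double-bonded chain carbon bound to a double-bonded chain carbon and it has not yet been measured.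

For the measured compounds named here, the one measured step is a step that the two limits leave unreadable from compound 1 to compound 2 and it carries no size over to this change.

No step beyond the scatter is therefore expected, and the estimated step is a number no higher from compound 2 to compound 3 (the limit leaves the size open) in this assay with no direction assigned.

For compound 3 the estimate is 500 ug/mL with an expected range from 250 ug/mL to 1000 ug/mL and a reading as a limit is likely.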

Compound 3, half-maximal cytotoxic concentration: 330 ug/mL
The estimate for compound 3 lay 1.5-fold (0.18 log units) above the measured number; the measured number falls inside the stated range.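

In this assay, compound 3 gives a real number, 330 ug/mL, so the 2-iodoethenyl group brings this position within the measurable range. Compound 1 and compound 2 each read only as a limit: the limit of > 500 ug/mL in this assay, at which 2 of the 3 values shown sit.

Iodo in place of chloro gives an at least 1.5-fold lower number from compound 2 to compound 3 (0.18 log units; that floor lies within the scatter), and iodo in place of bromo gives an at least 1.5-fold lower number from compound 1 to compound 3 (0.18 log units; that floor lies within the scatter); both sizes are floors only.

Still open, as far as these compounds go, is how a non-halogen group at this place, such as an amine, a carboxylic acid or a longer chain, would read in this assay. From the compounds shown here alone, the true size of both steps also remains open.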